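The compounds below may be only part of what the source reports. "The series", "measured", "known", "first", "only" and "open" are said of these compounds alone.

In a functional assay on A2780 cells (Homo sapiens) for antiproliferative activity, read by fluorescence, with a stated time of 72 h (a higher number here means a weaker inhibitor, a lower number a stronger inhibitor), compound 1 `CC(C)(C)C(=O)N1Cc2c(NC(=O)c3cccnc3)n[nH]c2C1(C)C` gives 690 nM and compound 2 `CN1CCC(C(=O)N2Cc3c(NC(=O)NCc4ccccc4)n[nH]c3C2(C)C)CC1` gives 2680 nM as the higher of the two numbers, which makes compound 2 the weaker inhibitor by a gap beyond the usual scatter. Compound 3 `CN1CCC(C(=O)N2Cc3c(NC(=O)c4ccco4)n[nH]c3C2(C)C)CC1` has not been measured yet. The change furan-2-yl in place of benzylamino on a carbonyl carbon puts furan-2-yl in place of benzylamino on a carbonyl carbon, and this is how compound 3 differs from compound 2. Among the compounds with values here, no two measured compounds differ in one place only, so no measured step guides this change directly. The one hint is weak: like compound 3, compound 1 carries no benzylamino group, and compound 1 gives 690 nM in that measurement. The expected step of a 3.0-fold lower number from compound 2 to compound 3 (0.47 log units; beyond the scatter) is estimated as moderate and toward a lower number, meaning a stronger inhibitor. For compound 3 the estimate is 900 nM with an expected range from 300 nM to 2600 nM in this assay when it is tested.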

Compound 3, half-maximal inhibitory concentration: > 5000 nM
Compound 3 gave a limit, no number; the forecaster's own chance of this, stated with the estimate: 2%; middle value at least 5.5-fold (0.74 log units) from the limit.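

In this assay compound 3 gives > 5000 nM, which is a limit of the assay and not a number. Read as a floor, the change is an at least 1.8-fold higher number from compound 2 to compound 3 (0.27 log units; that floor lies within the scatter), so putting furan-2-yl in place of benzylamino on this carbonyl carbon brings no lower number, and losing benzylamino does not by itself give a stronger inhibitor here. How far the number actually rises cannot be told, because the reading stops at a limit: the limit of > 5000 nM in this assay, at which 1 of the 3 values shown sits.

Still open, from the compounds shown here alone, is which part of benzylamino matters more: a benzyl group would keep the benzene ring without the nitrogen, and a methylamino group would keep the nitrogen without the ring. Also open, going by these compounds, is whether a thiophen-2-yl group on the same carbonyl carbon would read any differently from furan-2-yl.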